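A sulfur group exchanged on a propoxy compound

This account rests on a few compounds, and the source may have more. Where it says the series, first, only, none or still open, it means among the compounds named here.

Values in a functional assay on the whole organism with Canis familiaris (Canis lupus familiaris) as the target (on this read-out higher numbers stand for an effect only at larger amounts of compound and lower numbers for an effect already at smaller amounts), are these
Compound 1 `CCOc1cc([S+](C)[O-])ccc1-c1nc2cc[nH]cc-2n1` gives 0.1 mg/kg
Compound 2 `CCCOc1cc(SC)ccc1-c1nc2cc[nH]cc-2n1` gives 1.2 mg/kg

Of these two numbers, compound 2 stands highest, and compound 1 lies lower by more than the scatter. The change to compound 3 `CCCOc1cc([S+](C)[O-])ccc1-c1nc2cc[nH]cc-2n1` is a group of 3 heavy atoms (1 carbon, 1 oxygen, 1 sulfur; no ring) in place of a group of 2 heavy atoms (1 carbon, 1 sulfur; no ring), on an aromatic carbon on an aromatic carbon. For the measured compounds named here, no measured step isolates this change. Compound 1 carries the entering group but no propoxy group and gives 0.1 mg/kg with it, so a lower number beyond the scatter is expected. The expected step is a 4.8-fold lower number from compound 2 to compound 3 (0.68 log units; beyond the scatter) in that direction. Compound 3 is estimated at 0.25 mg/kg with 0.07 mg/kg to 0.9 mg/kg as the expected range.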

Compound 3, dose for half-maximal effect: 1 mg/kg
Compound 3: the middle estimate sits 4.0-fold (0.60 log units) below what was measured, outside the stated range (above it).
By their numbers in this assay, from the lowest: compound 1; then compounds 3 and 2 (each within the scatter of the next).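

In this assay, the exchange of methylsulfanyl for the new sulfur group on the aromatic carbon gives a 1.2-fold lower number from compound 2 to compound 3 (0.08 log units; within the scatter) and so does not separate the two sulfur groups on the propoxy compounds. For the compounds shown here, with that sulfur group held constant, the methyl added to the chain gives a 10-fold higher number from compound 1 to compound 3 (1.00 log units; beyond the scatter) and marks the chain on the oxygen as the one change here that exceeds the scatter. Nothing available explains either result.

The compounds shown leave open how an amine or a carboxylic acid would fare on this aromatic carbon. They also leave open whether a chain longer than propoxy would extend the difference seen with the chain.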